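Aryl thiosemicarbazones of a quinoline-derived core

The source may report more compounds than this note shows. Statements on the series, on what has been measured and on what is new or still open speak of the compounds shown alone.

Compound 1 `NC(=S)N/N=C/c1ccc2ccccc2n1` gives > 100000 nM in a functional assay on HL-60 cells (Homo sapiens) for antiproliferative activity, read by sulforhodamine B assay, with a stated time of 72 h; on this read-out higher numbers stand for weaker inhibition and lower numbers for stronger inhibition.
Compound 2 `Cc1ccc(NC(=O)N/N=C/c2ccc3ccccc3n2)cc1` gives > 100000 nM in this assay.
Compound 3 `CN(C)C(=S)N/N=C/c1nc2ccccc2s1` gives 3680 nM in this assay.

Compound 1 stands at the assay limit: its value of > 100000 nM is a limit, not a number. Compound 2 likewise reaches only a limit, > 100000 nM. Among the measured compounds shown here, of the three measured compounds, only compound 3, with its value of 3680 nM, gives a number; compound 3 carries a different core and two methyl groups on the thioamide nitrogen, and no single-change step connects it to compound 1 or compound 2.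

The unmeasured compound 4 `S=C(N/N=C/c1ccc2ccccc2n1)Nc1ccccc1Br` differs from compound 1 in one place: 2-bromophenyl in place of hydrogen on an amide-type nitrogen. Because compound 1 sits at the limit of > 100000 nM in this assay, at which 2 of the 3 values shown sit, any measurable value for compound 4 would already mean a gain. Compound 3 shows that a thiosemicarbazone bearing a substituted thioamide nitrogen can fall inside the measurable range, but its core differs, so the weight of this is limited.

Compound 4 is therefore expected to give 20000 nM, between 3000 nM and 100000 nM, an estimated step of an at least 5.0-fold lower number from compound 1 to compound 4 (0.69 log units; beyond the scatter) toward stronger inhibition, with a real chance that only a limit is returned.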

Compound 4, half-maximal inhibitory concentration: > 100000 nM
Compound 4 was reported as a limit (the forecaster's own chance of this, stated with the estimate: 35%); middle value at least 5.0-fold (0.69 log units) from the limit.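

Compound 1 and compound 4 each return only a limit, so the effect of 2-bromophenyl in place of hydrogen cannot be read as a step between them: the limit of > 100000 nM in this assay, at which 3 of the 4 values shown sit.

The compounds shown leave open whether any group on that amide-type nitrogen can bring the core of compound 1 into the measurable range.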